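The source may hold more compounds than are shown below. What is called first, only, known or untested is meant among the compounds shown, and "the series" means these compounds.

Compound 2, with the structure `COc1cc(Cc2cnc(/N=C3\C(=O)N(CN4CCN(c5ccc(Cl)cc5)CC4)c4ccc(Cl)cc43)nc2N)cc(OC)c1OC`, belongs to a small set of related compounds. In an ADME assay on CCRF-CEM cells (Homo sapiens) for cytotoxicity, read by MTT assay, with a stated time of 5 days (on this read-out higher numbers stand for lower toxicity in this test and lower numbers for higher toxicity in this test), compound 2 gives 40.1 ug/mL. Its closest companion among the measured compounds is compound 3, whose structure is `COc1cc(Cc2cnc(/N=C3\C(=O)N(CN4CCN(c5c(F)cc6c(=O)c(C(=O)O)cn(C7CC7)c6c5F)CC4C)c4ccc(Cl)cc43)nc2N)cc(OC)c1OC`; in this assay compound 3 gives 67 ug/mL, and the two numbers lie within the usual scatter of each other, so nothing separates them with confidence. Compound 1, with the structure `CCCCN(CCCC)CN1C(=O)/C(=N\c2ncc(Cc3cc(OC)c(OC)c(OC)c3)c(N)n2)c2cc(Cl)ccc21`, gives "not determined" (no result reported) in this assay, so no number is reported for it. For the measured compounds named here, no single-change step between two measured compounds is available here, so there is no measured precedent for what one swap of a side group does to the cytotoxicity read-out.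

Compound 4 has the structure `COc1cccc(N2CCN(CN3C(=O)/C(=N\c4ncc(Cc5cc(OC)c(OC)c(OC)c5)c(N)n4)c4cc(Cl)ccc43)CC2)c1`. It differs from compound 2 in one place: 3-methoxyphenyl in place of 4-chlorophenyl on an amine nitrogen in a ring. Since the two measured compounds that carry different groups on that ring nitrogen still sit within the scatter of each other, the expected step from compound 2 to compound 4 in this assay is a 1.0-fold higher number from compound 2 to compound 4 (0.02 log units; within the scatter), that is, none beyond the scatter. On that basis compound 4 is expected to give about 42 ug/mL, with a likely range from 20 ug/mL to 85 ug/mL.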

Compound 4, half-maximal cytotoxic concentration: 23.3 ug/mL
The estimate for compound 4 lay 1.8-fold (0.26 log units) above the measured number, within the range that was stated.
By their numbers in this assay, from the lowest: compounds 4, 2 and 3 (each within the scatter of the next, the first and the last beyond it).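

For the compounds shown here, this is the first single-change step at this position, the amine nitrogen in the six-membered non-aromatic ring with 2 nitrogen. In this assay, 3-methoxyphenyl in place of 4-chlorophenyl gives a 1.7-fold lower number from compound 2 to compound 4 (0.24 log units; within the scatter). Exchanging the chlorine-bearing aromatic ring for one with a methoxy group, which adds a hydrogen-bond acceptor, therefore leaves the read-out no further apart than repeated measurements of one compound might be, and no measurement at hand offers an explanation for this result.

From the compounds shown here alone, whether a benzyl group or a pyridine ring on that ring nitrogen would also stay within the scatter of compound 2 remains open. Going by these compounds alone, with only this one step in this assay, it is also unknown whether the same swap would behave alike in other cells.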